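Three pyridine-linked phenols at the assay limit, a fourth predicted

The source may report more compounds than this note shows. Statements on the series, on what has been measured and on what is new or still open speak of the compounds shown alone.

Compound 1 has the structure `Oc1ccccc1-c1cc(-c2ccc(F)cc2)cc(-c2ccccc2O)n1`. In a functional assay on DU-145 cells (Homo sapiens) for inhibition (a higher number here means a weaker inhibitor, a lower number a stronger inhibitor), compound 1 gives > 50000 nM, which is a limit of the assay rather than a number. Compound 2, with the structure `Oc1cccc(-c2cc(-c3ccc(F)cc3)cc(-c3ccccc3O)n2)c1`, differs from compound 1 by 3-hydroxyphenyl in place of 2-hydroxyphenyl on an aromatic carbon. In this assay compound 2 gives > 50000 nM, again a limit. The resulting step that the two limits leave unreadable from compound 1 to compound 2 cannot be read because both ends are limits. Compound 3 has the structure `Oc1cccc(-c2cc(-c3ccccc3OC(F)(F)F)cc(-c3ccccc3O)n2)c1`; how its core differs from that of compound 1 is not broken down here. In this assay compound 3 gives > 50000 nM, also a limit. All three measured values are tied to the limit of > 50000 nM in this assay, at which 3 of the 3 values shown sit.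

Compound 4, not yet measured, has the structure `Oc1cccc(-c2cc(-c3ccccc3OC(F)(F)F)cc(-c3cccc(O)c3)n2)c1` and differs from compound 3 by 3-hydroxyphenyl in place of 2-hydroxyphenyl on an aromatic carbon. Among the compounds with values here, this is the same kind of change as the one from compound 1 to compound 2, though the surroundings differ: in compound 1 the place is meta to a 2-hydroxyphenyl group and meta to a 4-fluorophenyl group, whereas in compound 3 it is meta to a 3-hydroxyphenyl group and meta to a large group. Because compound 3 sits at the limit of > 50000 nM in this assay, at which 3 of the 3 values shown sit, and the same kind of change left compound 2 at the limit, compound 4 is expected to remain unreadable in this assay, with the estimated step that the limit leaves unreadable from compound 3 to compound 4. The estimate for compound 4 is 100000 nM, most likely reported only as a limit.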

Compound 4, half-maximal inhibitory concentration: 5420 nM
Compound 4: middle estimate off by 18-fold (1.27 log units), on the high side, and the stated range ends above it.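

In this assay the exchange of 2-hydroxyphenyl for 3-hydroxyphenyl gave an at least 9.2-fold lower number from compound 3 to compound 4 (0.96 log units; beyond the scatter), and compound 4 is the only compound shown with a value that is not a limit. This shows that on the core of compound 3 the exchange can bring a readable result, but the size given is only a lower bound, because compound 3 itself stands at a limit, and the step from compound 1 to compound 2 cannot be read, because both of its ends are limits: the limit of > 50000 nM in this assay, at which 3 of the 4 values shown sit. The series therefore does not show that the change carries from one core to another: it went with a readable value on one core and with no readable value on the other, and a single readable pair gives no measure of how far the two cores differ in their response.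

The compounds shown leave open whether exchanging the remaining 2-hydroxyphenyl of compound 2 for 3-hydroxyphenyl, with 4-fluorophenyl kept, would also give a readable value. They also leave open whether the hydroxyl on these rings matters as such, or whether an amine or a carboxylic acid in its place would serve in the same way.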